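Working notes: 2-phenylethenyl in place of furan-3-yl

A few compounds are considered here, and "the series" means these few. Any claim that something is new, unique, unknown or untested is made for them only; others in the source may bear on it.

In a functional assay on NCI-H460 cells (Homo sapiens) for antiproliferative activity, with a stated time of 72 h (on this read-out lower numbers stand for stronger inhibition and higher numbers for weaker inhibition), compound 1 (`CCCC#Cc1cc([C@@H]2O[C@H](CO)[C@@H](O)[C@H]2O)n2ncnc(N)c12`) gives 400 nM while compound 2 (`Nc1ncnn2c([C@@H]3O[C@H](CO)[C@@H](O)[C@H]3O)cc(C#Cc3ccccc3)c12`) gives 38500 nM and compound 3 (`Nc1ncnn2c([C@@H]3O[C@H](CO)[C@@H](O)[C@H]3O)cc(-c3ccoc3)c12`) gives 1500 nM as the middle of the three numbers. Compound 4 (`Nc1ncnn2c([C@@H]3O[C@H](CO)[C@@H](O)[C@H]3O)cc(/C=C/c3ccccc3)c12`) carries 2-phenylethenyl in place of furan-3-yl on an aromatic carbon of the shared core. The closest measured comparison is a 26-fold lower number from compound 2 to compound 3 (1.41 log units; beyond the scatter) where furan-3-yl replaces 2-phenylethynyl, and a 96-fold higher number from compound 1 to compound 2 (1.98 log units; beyond the scatter) also leaves the phenyl-bearing alkyne on the weak side. Among the compounds with values here, no measured compound carries 2-phenylethenyl, so a higher number of smaller size is expected in this assay and the estimated step is a 5.3-fold higher number from compound 3 to compound 4 (0.73 log units; beyond the scatter) for now. Compound 4 is estimated at 8000 nM within a range of 1500 nM to 40000 nM as a working expectation.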

Compound 4, half-maximal inhibitory concentration: 3700 nM
Estimate against measurement, compound 4: 2.2-fold (0.33 log units) above; the measured number falls inside the stated range.
By their numbers in this assay, from the lowest: compound 1; then compound 3; then compound 4; then compound 2.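

In this assay the linker carrying the phenyl group matters strongly at this aromatic carbon: 2-phenylethenyl in place of 2-phenylethynyl gives a 10-fold lower number from compound 2 to compound 4 (1.02 log units; beyond the scatter), so phenyl alone does not set the weak number of the alkyne. Even so, 2-phenylethenyl stays on the weaker side of both other groups, with a 2.5-fold higher number from compound 3 to compound 4 (0.39 log units; beyond the scatter) against furan-3-yl and a 9.3-fold higher number from compound 1 to compound 4 (0.97 log units; beyond the scatter) against pent-1-yn-1-yl.

Nothing available explains these steps. As far as these compounds go, whether a saturated 2-phenylethyl chain or an aminomethyl group at this carbon would fall nearer compound 1 or compound 2 remains open.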